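Ester for Sulfone on the Side Chain of Compound 3

A few compounds are considered here, and "the series" means these few. Any claim that something is new, unique, unknown or untested is made for them only; others in the source may bear on it.

Three compounds have been measured in an assay on isolated protein for inhibition of cathepsin S (Homo sapiens); on this read-out lower numbers stand for stronger inhibition and higher numbers for weaker inhibition:
compound 1, `O=C(NCCNc1ccc(F)cc1)[C@H](CC1CCCCC1)Nc1nc2ccccc2o1`, gives 94 nM
compound 2, `C[C@@H](CN1CC(C)(C)c2cc(F)ccc21)NC(=O)[C@H](CC1CCCCC1)Nc1nc2cccc(Cl)c2o1`, gives 3 nM
compound 3, `CS(=O)(=O)CC[C@@H](CN1CCc2cc(F)ccc21)NC(=O)[C@H](CC1CCCCC1)Nc1nc2ccc(Cl)cc2o1`, gives 21 nM

Compound 3 stands in the middle of the three. Its number lies below that of compound 1, a gap that is beyond the scatter, and above that of compound 2, also beyond the scatter. Going by the values given here, neither compound 1 nor compound 2 differs from compound 3 in only one place, so no single step is computed among the measured compounds, and what their values show is only that the series spans a wide range.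

Compound 4, `CC(C)(C)OC(=O)C[C@@H](CN1CCc2cc(F)ccc21)NC(=O)[C@H](CC1CCCCC1)Nc1nc2ccc(Cl)cc2o1`, differs from compound 3 in a single place: tert-butoxycarbonyl in place of (methylsulfonyl)methyl on a saturated chain carbon, two bonds along the chain from an amide-type nitrogen. Among the compounds with values here, the leaving group and the entering group carry the same count of hydrogen-bond acceptors and no donors, and the data hold no measured step for a change at this chain carbon. The expected step from compound 3 to compound 4 in this assay is therefore small, around a 1.1-fold lower number from compound 3 to compound 4 (0.02 log units; within the scatter), with no clear direction beyond the scatter. Compound 4 is estimated to give 20 nM, between 6 nM and 65 nM.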

Compound 4, inhibition constant: 730 nM
Compound 4: middle estimate off by 37-fold (1.56 log units), on the low side; measured number above the stated range.
By their numbers in this assay, from the lowest: compound 2; then compound 3; then compound 1; then compound 4.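

The change of tert-butoxycarbonyl in place of (methylsulfonyl)methyl, on a saturated chain carbon, two bonds along the chain from an amide-type nitrogen, brings a 35-fold higher number from compound 3 to compound 4 (1.54 log units; beyond the scatter) in this assay and so gives the series its first single-place step. Until now the values showed only that the series spans a wide range; this step shows that this one position can by itself move the number by a large amount. The leaving and entering groups carry the same count of hydrogen-bond acceptors and no donors, so that count does not predict the outcome at this position.

The data offered here contain nothing that bears on why the number rises so far.

Which part of the entering group goes with the step stays open, since a methyl ester, a carboxylic acid or a primary amide on the same chain carbon would each set the tert-butyl part apart from the carbonyl part. Also open, on these data alone, is whether a sulfone on a longer chain would hold the value of compound 3, and whether the step keeps its size on other versions of the shared core.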